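Cyclohexyl for sec-Butyl: a Small Step Expected Again

This account rests on a few compounds, and the source may have more. Where it says the series, first, only, none or still open, it means among the compounds named here.

Of the compounds shown here, three of one family have been tested in a functional assay on Caco-2 cells (Homo sapiens), read by fluorescence, tested at 1 uM; on this read-out higher numbers stand for a weaker effect at the one concentration tested and lower numbers for a stronger effect. Compound 3 `CCC(C)NC(=C\C(=O)/C=C/c1ccc(OC(C)=O)c(OC)c1)/C=C/c1ccc(OC(C)=O)c(OC)c1` gives 95%. Compound 1 `COc1cc(/C=C/C(=O)/C=C(/C=C/c2ccc(OC(C)=O)c(OC)c2)NC2CCCCC2)ccc1OC(C)=O` differs from compound 3 only by cyclohexyl in place of sec-butyl on an amine nitrogen, and in this assay compound 1 gives 89%, so that the change yields a number 6 percentage points lower from compound 3 to compound 1 (within the scatter). Compound 2 `CCC(C)NC(=C\C(=O)/C=C/c1ccc(O)cc1)/C=C/c1ccc(O)cc1` carries a different core; the difference between the cores of compound 2 and compound 3 is not broken down here. In this assay compound 2 gives 102%, a value that lies within the scatter of the value of compound 3 and beyond the scatter relative to the value of compound 1.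

Compound 4 `O=C(/C=C(/C=C/c1ccc(O)cc1)NC1CCCCC1)/C=C/c1ccc(O)cc1` has not been measured. It is reached from compound 2 by cyclohexyl in place of sec-butyl on an amine nitrogen, the same change on the other core. Because the measured change gave a number 6 percentage points lower from compound 3 to compound 1 (within the scatter), a similarly small step is expected from compound 2 to compound 4, namely a number 6 percentage points lower from compound 2 to compound 4 (within the scatter). Compound 4 is therefore estimated to give about 96% in this assay, most likely between 84% and 108%.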

Compound 4, a percentage reported as activity, at one concentration (the size of the read-out at that concentration, not a potency): 97%
Beside the measured number, compound 4's estimate is 1 percentage points below it, within the range that was stated.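

On the core of compound 2, cyclohexyl in place of sec-butyl on the amine nitrogen gives in this assay a number 5 percentage points lower from compound 2 to compound 4 (within the scatter), so the change stays small here too. Set beside the earlier step, the same change behaves alike on the two cores: the same change on two cores in this assay, a number 6 percentage points lower (within the scatter) from compound 3 to compound 1 and a number 5 percentage points lower (within the scatter) from compound 2 to compound 4, 1 percentage points apart, within the scatter of two such steps. This shows that, for these two cores, the step carries over as a small one, but since each step lies within the scatter, it does not show that cyclohexyl acts any differently from sec-butyl, and two cores read at one concentration say nothing about potency or about other cores in the series.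

The compounds shown leave open what other groups on the amine nitrogen would do, such as a benzyl group, a longer chain or a chain ending in a carboxylic acid. They also leave open whether the step would stay this small on a third core.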